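The source may hold more compounds than are shown below. What is called first, only, known or untested is meant among the compounds shown, and "the series" means these compounds.

Compound 2, whose structure is `COc1ccccc1-c1cn2ccnc2c(-c2ccc3ncn(C4CCCCC4)c3c2)n1`, and compound 1, whose structure is `Fc1ccc(-c2cn3ccnc3c(-c3ccc4ncn(C5CCCCC5)c4c3)n2)cc1`, share one core and differ only in the aromatic group attached to it. In a functional assay on 786-0 cells (Homo sapiens) for inhibition, read by sulforhodamine B assay, with a stated time of 48 h, tested at 10 uM (on this read-out lower numbers stand for less inhibition and higher numbers for more inhibition at the one concentration tested (going by the name of the read-out)), compound 1 gives 11.2%, and compound 2 gives 12.3%. For the measured compounds named here, the only measured step, a number 1.1 percentage points higher from compound 1 to compound 2 (within the scatter), stays within the usual scatter, so the two numbers sit too close together for either compound to count as the more inhibiting one; compound 2 simply carries the larger of two nearly equal readings, both well short of half inhibition at the tested concentration.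

Compound 3, whose structure is `c1csc(-c2cn3ccnc3c(-c3ccc4ncn(C5CCCCC5)c4c3)n2)c1`, is the next step: thiophen-2-yl in place of 2-methoxyphenyl on an aromatic carbon. Going by the values given here, the one step seen so far swapped one six-membered aromatic ring for another and moved the read-out hardly at all. Among the compounds with values here, no step yet shows what a five-membered ring with a sulfur does in this position, so the expectation rests on that single quiet step. The step of a number 0.3 percentage points lower from compound 2 to compound 3 (within the scatter) is therefore expected to stay within the scatter. Compound 3 is estimated to give 12%, within a range from 0% to 28%.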

Compound 3, a percentage reported as inhibition, at one concentration (the size of the read-out at that concentration, not a potency): 4.1%
For compound 3 the middle estimate is 7.9 percentage points above the measured one, within the range that was stated.
By their numbers in this assay, from the lowest: compounds 3, 1 and 2 (each within the scatter of the next).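

The position on the aromatic carbon next to the ring nitrogen now has its first change of ring type: a five-membered aromatic ring with one sulfur takes the place of a six-membered aromatic ring of carbon only. In this assay, the exchange for 2-methoxyphenyl gives a number 8.2 percentage points lower from compound 2 to compound 3 (within the scatter), and the exchange for 4-fluorophenyl gives a number 7.1 percentage points lower from compound 1 to compound 3 (within the scatter), so neither step separates thiophen-2-yl from the group it replaces, even though it has fewer heavy atoms than 2-methoxyphenyl and changes both ring size and ring atoms. All three aromatic groups therefore give readings that cannot be told apart at the one concentration tested, and no further evidence is available to explain the readings.

These three compounds leave open whether any group on this carbon can move the reading beyond the usual scatter, for example an amine, a carboxylic acid or a longer alkyl chain in place of the aromatic ring. They also leave open how potent any of these compounds is, since a single-concentration reading does not give a potency.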